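The compounds below may be only part of what the source reports. "The series", "measured", "known", "first", "only" and "open" are said of these compounds alone.

Compound 1 `c1ccc(-c2noc(-c3ccncc3)n2)cc1`: 657000 nM
Compound 2 `COc1ccc(-c2noc(-c3ccccc3)n2)cc1OC1CCCC1`: > 1000000 nM

Both compounds were tested in a functional assay on DU-145 cells (Homo sapiens) for antiproliferative activity, read by MTT assay, with a stated time of 24 h; on this read-out higher numbers stand for weaker inhibition and lower numbers for stronger inhibition. Compound 2 gives no number there. Compound 2 stands at > 1000000 nM, which is a limit of the assay and not a measured value. The evidence is correspondingly thin, with the limit of > 1000000 nM in this assay, at which 1 of the 2 values shown sits. Among the compounds with values here, compound 1, by contrast, gives a true reading of 657000 nM, though no single-point step connects it to compound 2.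

Compound 3 `COc1ccc(-c2noc(-c3ccncc3)n2)cc1OC1CCCC1` keeps the substituted ring of compound 2 and carries pyridin-4-yl in place of phenyl on an aromatic carbon. Compound 1 bears the same pyridin-4-yl and reads 657000 nM, so a reading within the range of the assay seems plausible for compound 3, though this rests on one compound only. A modest shift toward stronger inhibition is therefore expected, and a further limit reading remains possible. In this assay the expected change is an at least 2.5-fold lower number from compound 2 to compound 3 (0.39 log units; beyond the scatter). For compound 3 the estimate is 400000 nM, with an expected range of 80000 nM to 1000000 nM.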

Compound 3, half-maximal inhibitory concentration: > 1000000 nM
Compound 3 gave a limit, no number (the forecaster's own chance of this, stated with the estimate: 30%); middle value at least 2.5-fold (0.39 log units) from the limit.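

In this assay, compound 2 and compound 3 both give only a limit, so the step between them cannot be read. The evidence stops at that ceiling: the limit of > 1000000 nM in this assay, at which 2 of the 3 values shown sit.

The compounds shown leave open whether pyridin-4-yl in place of phenyl on an aromatic carbon changes inhibition in this series.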